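The source may hold more compounds than are shown below. What is called first, only, known or untested is meant among the compounds shown, and "the series" means these compounds.

In an ADME assay on SH-SY5Y cells (Homo sapiens) for cytotoxicity, read by MTT assay, with a stated time of 72 h (on this read-out lower numbers stand for stronger inhibition and higher numbers for weaker inhibition), compound 1 (`O=C(CN1CCN(C(=O)c2ccc(Br)cc2)CC1)N1CCN(CCCc2c[nH]c3ccc(F)cc23)CC1`) gives 47400 nM as its reading. Compound 2 (`COc1ccc2[nH]cc(CCCN3CCN(C(=O)CN4CCN(C(=O)c5ccccc5)CC4)CC3)c2c1`) reads > 200000 nM and this is a limit, not a number. Compound 3 (`COc1ccc2[nH]cc(CCCN3CCN(C(=O)CN4CCN(C(=O)c5ccc(Cl)cc5)CC4)CC3)c2c1`) gives 159000 nM as the higher of the two true numbers, with compound 1 lower by a margin beyond the scatter. Compound 4 (`COc1ccc2[nH]cc(CCCN3CCN(C(=O)CN4CCN(C(=O)c5ccc(Br)cc5)CC4)CC3)c2c1`) brings bromo in place of chloro on an aromatic carbon in the swap of bromo for chloro, para to a large group. Going by the values given here, the one measured step at this place is an at least 1.2-fold lower number from compound 2 to compound 3 (0.09 log units; that floor lies within the scatter) for chloro in place of hydrogen. No step beyond the scatter is therefore expected in this assay here. Compound 1 also holds a 4-bromophenyl but differs in the core, which widens the range toward lower numbers. The estimated change is a 1.2-fold lower number from compound 3 to compound 4 (0.09 log units; within the scatter) and no more than scatter. Expected for compound 4 is 130000 nM (estimated range 65000 nM to 200000 nM).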

Compound 4, half-maximal inhibitory concentration: 150000 nM
Beside the measured number, compound 4's estimate is 1.2-fold (0.06 log units) below it; measured number inside the range.
By their numbers in this assay, from the lowest: compound 1; then compounds 4 and 3 (each within the scatter of the next). At a limit, above all of these: compound 2.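

In this assay, 4-chlorophenyl to 4-bromophenyl gives a 1.1-fold lower number from compound 3 to compound 4 (0.03 log units; within the scatter), so the two halogens are not told apart at this position. Compound 2 stands at a limit, not a number, so an at least 1.3-fold lower number from compound 2 to compound 4 (0.12 log units; that floor lies within the scatter) gives only a floor and the effect of either halogen over hydrogen stays unresolved: the limit of > 200000 nM in this assay, at which 1 of the 4 values shown sits.

Of the new steps, only a 3.2-fold higher number from compound 1 to compound 4 (0.50 log units; beyond the scatter), for methoxy in place of fluoro on an aromatic carbon, lies beyond the scatter, and that change sits on the core rather than at this position.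

Open, as far as these compounds go, is whether an amine or a carboxylic acid on this aromatic carbon would move the reading beyond the scatter.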